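Swapping methyl for chloro on the most active compound

A few compounds are considered here, and "the series" means these few. Any claim that something is new, unique, unknown or untested is made for them only; others in the source may bear on it.

Compound 1 `COc1ccccc1-c1ccc2ncn(-c3cc(OC)c(OC)c(OC)c3)c2c1` gives 1750 nM
Compound 2 `COc1cc(-n2cnc3ccc(-c4cccc(O)c4)cc32)cc(OC)c1OC` gives 350 nM
Compound 3 `COc1cc(-n2cnc3ccc(-c4ccc(C)cc4)cc32)cc(OC)c1OC` gives 110 nM

All three compounds were tested in a functional assay on MCF7 cells (Homo sapiens) for antiproliferative activity, read by MTT assay, with a stated time of 72 h; on this read-out lower numbers stand for stronger inhibition and higher numbers for weaker inhibition. Compound 3 has the lowest number of the three, and its steps to both others lie beyond the scatter. Compound 4 `COc1cc(-n2cnc3ccc(-c4ccc(Cl)cc4)cc32)cc(OC)c1OC` differs from it in one place: chloro in place of methyl on an aromatic carbon. Its 4-methylphenyl becomes 4-chlorophenyl, with chloro in place of methyl on an aromatic carbon.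

Among the measured compounds shown here, two measured steps bear on this change. Replacing 2-methoxyphenyl with 4-methylphenyl gave a large step, a 16-fold lower number from compound 1 to compound 3 (1.20 log units; beyond the scatter). Replacing 3-hydroxyphenyl with 4-methylphenyl gave a modest one, a 3.2-fold lower number from compound 2 to compound 3 (0.50 log units; beyond the scatter). Both show that this aryl group matters, but both also swap one substituted phenyl for a differently placed one. For the measured compounds named here, no measured pair compares methyl with chloro at the same place, so the direction is open, and no step beyond the scatter is expected in this assay. The expected change is a 1.2-fold higher number from compound 3 to compound 4 (0.07 log units; within the scatter). For compound 4 the estimated value is 130 nM, within an expected range of 50 nM to 350 nM.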

Compound 4, half-maximal inhibitory concentration: 1320 nM
The estimate for compound 4 lay 10-fold (1.01 log units) below the measured number; measured number outside the range, above it.
By their numbers in this assay, from the lowest: compound 3; then compound 2; then compounds 4 and 1 (each within the scatter of the next).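

In this assay this place on the aromatic ring proves sensitive to a change of one heavy atom: chloro in place of methyl gives a large step (a 12-fold higher number from compound 3 to compound 4 (1.08 log units; beyond the scatter)). The low number of compound 3 therefore depends on the methyl itself and not simply on having a 4-substituted phenyl, since the 4-chlorophenyl is modestly worse than the 3-hydroxyphenyl (a 3.8-fold higher number from compound 2 to compound 4 (0.58 log units; beyond the scatter)) and lies within the scatter of the 2-methoxyphenyl (a 1.3-fold lower number from compound 1 to compound 4 (0.12 log units; within the scatter)). Nothing available explains why these two groups differ so much.

On these data alone, it remains open whether the preference is specific to methyl or extends to a longer chain such as ethyl. Groups such as an amine or a carboxylic acid at this place also remain untested among the compounds shown.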